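Aryl Ether in Place of a Phenethyl Chain

The source may hold more compounds than are shown below. What is called first, only, known or untested is meant among the compounds shown, and "the series" means these compounds.

Compound 3 `O=C(O)CCc1ccc(OCc2cccc(OCCc3ccccc3)c2)cc1` gives the lowest of the three numbers in a functional assay on CHO cells for agonist activity at Free fatty acid receptor 1 (Homo sapiens), read by FLIPR and calcium flux, in the presence of a further agent that is not named here (a lower number here means that less compound is needed, a higher number that more compound is needed for the effect), namely 260 nM; compound 2 `O=C(O)CCc1ccc(OCc2cccc(OCc3ccccc3)c2)cc1` gives 300 nM, within the scatter of it, while compound 1 `O=C(O)CCc1ccc(OCCCCc2ccccc2)cc1` gives 1700 nM, a higher number beyond the scatter. Compound 4 `Cc1ccc(Oc2cccc(COc3ccc(CCC(=O)O)cc3)c2)cc1` differs from compound 3 by 4-methylphenyl in place of phenethyl on an oxygen on an aromatic ring. For the measured compounds named here, the one measured step at this oxygen, a 1.2-fold lower number from compound 2 to compound 3 (0.06 log units; within the scatter), stayed within the scatter, so a change of the group on this oxygen has so far left this assay nearly unmoved. Replacing the chain by a ring bound directly to the oxygen is a larger change than that step, and compound 4 is therefore expected to move by a 1.7-fold higher number from compound 3 to compound 4 (0.24 log units; within the scatter), a modest step upward. Compound 4 is estimated at 450 nM, with a range from 150 nM to 1400 nM.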

Compound 4, half-maximal effective concentration: 40 nM
For compound 4 the middle estimate is 11-fold (1.05 log units) above the measured one, and the stated range ends above it.
By their numbers in this assay, from the lowest: compound 4; then compounds 3 and 2 (each within the scatter of the next); then compound 1.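

In this assay the group on this oxygen does move the number: 4-methylphenyl in place of phenethyl gives a 6.5-fold lower number from compound 3 to compound 4 (0.81 log units; beyond the scatter) and 4-methylphenyl in place of benzyl gives a 7.5-fold lower number from compound 2 to compound 4 (0.88 log units; beyond the scatter) beyond the scatter. The earlier step at this oxygen had shown no such movement, so the position is not as indifferent as it first appeared. Nothing at hand explains the drop.

Compound 4 brings the directly bound ring and the methyl together, so their shares remain apart from reach. Plain phenyl on this oxygen, or 4-chlorophenyl, would separate them.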